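Swapping phenyl for sulfamoyl in a small cytotoxic series

This account rests on a few compounds, and the source may have more. Where it says the series, first, only, none or still open, it means among the compounds named here.

In a functional assay on MIA PaCa-2 cells (Homo sapiens) for cytotoxicity, read by MTT assay, with a stated time of 72 h (on this read-out higher numbers stand for weaker inhibition and lower numbers for stronger inhibition), compound 1 (`O=C1C(Nc2ccc(-c3ccccc3)cc2)=CC(=O)c2ncncc21`) gives 900 nM and compound 3 (`COc1cc(NC2=CC(=O)c3ncncc3C2=O)cc(OC)c1OC`) gives 1500 nM as numbers within the usual scatter of each other. The shared core alone, compound 2 (`O=C1C=CC(=O)c2ncncc21`), gives 9400 nM as a number higher than that of compound 1 by more than the scatter. Compound 1 therefore stands together with compound 3 at the low end of the three numbers.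

Compound 4 (`NS(=O)(=O)c1ccc(NC2=CC(=O)c3ncncc3C2=O)cc1`) differs from compound 1 in one place, with sulfamoyl in place of phenyl on an aromatic carbon, para to a large group (sulfamoyl in place of phenyl on an aromatic carbon). Among the compounds with values here, no measured pair isolates this change, so any expectation for it is indirect. Compound 1 at 900 nM and compound 3 at 1500 nM carry different groups on their aromatic rings and still agree within the scatter, which argues against expecting a large step. Compound 4 also keeps the aromatic ring that compound 2 at 9400 nM lacks. A modest move toward a higher number, not clearly beyond the scatter, is expected, an estimated step of a 1.9-fold higher number from compound 1 to compound 4 (0.28 log units; within the scatter) in this assay overall. For compound 4 the expected value is 1700 nM with an estimated range from 550 nM to 5000 nM in this measurement.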

Compound 4, half-maximal inhibitory concentration: > 10000 nM
Compound 4 ended at the assay's limit (the forecaster's own chance of this, stated with the estimate: 3%); at least 5.8-fold (0.76 log units) between middle value and limit.
By their numbers in this assay, from the lowest: compounds 1 and 3 (each within the scatter of the next); then compound 2. At a limit, above all of these: compound 4.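

In this assay, this position on the aromatic carbon, para to a large group, proves sensitive to what it carries: sulfamoyl in place of phenyl gives an at least 11-fold higher number from compound 1 to compound 4 (1.04 log units; beyond the scatter), a large step beyond the scatter. Within the data shown here, this is the first pair that differs in one place, so the earlier compounds could not show that a change at this position alone can carry a step of this size. Compound 4 gives > 10000 nM, which is a limit of the assay and not a number: the limit of > 10000 nM in this assay, at which 1 of the 4 values shown sits.

The change takes away a six-membered aromatic ring of carbon only and brings in a group with a hydrogen-bond donor and hydrogen-bond acceptors, and this single pair cannot say which of these matters, nor how far the true value of compound 4 lies past the limit. Also open, as far as these compounds go, is how the position responds to other groups, such as a chlorine, an amine or a carboxylic acid, which would show whether the loss follows from losing phenyl or from sulfamoyl itself.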